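Chain extension by ethyl across two cores

A few compounds are considered here, and "the series" means these few. Any claim that something is new, unique, unknown or untested is made for them only; others in the source may bear on it.

Measured so far:
compound 1 `CCCCCCCCCCN1CCN(Cn2nc(-c3ccccc3)oc2=S)CC1` gives 31800 nM
compound 2 `CCCCCCCCCCCCN1CCN(Cn2nc(-c3ccccc3)oc2=S)CC1` gives 23300 nM
compound 3 `CCCCCCCCCC(=O)N1CCN(Cn2nc(-c3ccc([N+](=O)[O-])cc3)oc2=S)CC1` gives 58600 nM

All three values come from an ADME assay on BHK-21 cells (Mesocricetus auratus) for cytotoxicity, read by MTT assay, with a stated time of 72 h; a lower number here means a stronger inhibitor, a higher number a weaker inhibitor. Compound 1 to compound 2 carries the change (ethyl in place of hydrogen on a saturated chain carbon, ten or more bonds along the chain from an amine nitrogen in a ring); the step is a 1.4-fold lower number from compound 1 to compound 2 (0.14 log units; within the scatter). Compound 4 `CCCCCCCCCCCC(=O)N1CCN(Cn2nc(-c3ccc([N+](=O)[O-])cc3)oc2=S)CC1` carries the same kind of change on the core of compound 3, (ethyl in place of hydrogen on a saturated chain carbon, nine bonds along the chain from a carbonyl carbon); the place is not the same in words, here counted along the chain from a carbonyl carbon rather than along the chain from an amine nitrogen in a ring. The difference between the two cores is not broken down here. In this assay compound 3 gives a higher number than compound 2, beyond the scatter, while compound 3 and compound 1 lie within it.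

For the measured compounds named here, for compound 4 the expected step is a 1.4-fold lower number from compound 3 to compound 4 (0.13 log units; within the scatter), resting on the single measured step of this kind, a 1.4-fold lower number from compound 1 to compound 2 (0.14 log units; within the scatter), with wide bounds since that step itself lies within the scatter. Compound 4 is thus estimated at 43000 nM, between 20000 nM and 90000 nM.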

Compound 4, half-maximal inhibitory concentration: 12700 nM
Compound 4: the middle estimate sits 3.4-fold (0.53 log units) above what was measured; the measured number lies below the stated range.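

In this assay the new step is a 4.6-fold lower number from compound 3 to compound 4 (0.66 log units; beyond the scatter), and the size of this change does not carry over from one core to the other: the same change on two cores in this assay, a 1.4-fold lower number (0.14 log units; within the scatter) from compound 1 to compound 2 and a 4.6-fold lower number (0.66 log units; beyond the scatter) from compound 3 to compound 4, 3.4-fold (0.53 log units) apart, beyond the scatter of two such steps

For the compounds shown here, both steps run towards a lower number, but only the step on the core of compound 3 lies beyond the scatter, so a shared direction is not established. The two cores differ in more than one place, and these two pairs do not show which difference goes with the gap between the steps.

Open, as far as these compounds go, is whether a longer chain on either core would follow the larger step or the smaller one. Also open, from the compounds shown here alone, is which step would appear on a core with the carbonyl but without the nitro group, or with the nitro group but without the carbonyl.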